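A few compounds are considered here, and "the series" means these few. Any claim that something is new, unique, unknown or untested is made for them only; others in the source may bear on it.

Measured in a functional assay on MCF7 cells (Homo sapiens) for antiproliferative activity, read by MTT assay, with stated times of 24 h and 72 h; on this read-out lower numbers stand for stronger inhibition and higher numbers for weaker inhibition:
- compound 1 `COc1cc(N2C(=O)[C@@H](Oc3ccccc3)[C@H]2c2ccc(Br)cc2)cc(OC)c1OC`: 48000 nM
- compound 2 `COc1cc(N2C(=O)[C@@H](Oc3ccccc3)[C@H]2c2ccc(N(C)C)cc2)cc(OC)c1OC`: 31000 nM

For the measured compounds named here, compound 2 stands within the scatter of compound 1, the only other compound measured. Compound 3 `COc1cc(N2C(=O)[C@@H](Oc3ccccc3)[C@H]2c2ccc3ccccc3c2)cc(OC)c1OC` has naphthalen-2-yl in place of 4-(dimethylamino)phenyl on a saturated ring carbon. Going by the values given here, only one measured step bears on this change: a 1.5-fold lower number from compound 1 to compound 2 (0.19 log units; within the scatter). It altered the same aromatic group, yet it stayed small. Among the compounds with values here, no measured compound carries naphthalen-2-yl, so the expectation is loose. No step beyond the scatter is expected in this assay, and the estimate is a 1.2-fold lower number from compound 2 to compound 3 (0.09 log units; within the scatter). Compound 3 is expected at 25000 nM, with an estimated range of 7000 nM to 70000 nM.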

Compound 3, half-maximal inhibitory concentration: 282000 nM
Beside the measured number, compound 3's estimate is 11-fold (1.05 log units) below it, outside the stated range (above it).
By their numbers in this assay, from the lowest: compounds 2 and 1 (each within the scatter of the next); then compound 3.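

In this assay, this saturated ring carbon turns out to be sensitive to its aromatic group: naphthalen-2-yl gives a 9.1-fold higher number from compound 2 to compound 3 (0.96 log units; beyond the scatter) and a 5.9-fold higher number from compound 1 to compound 3 (0.77 log units; beyond the scatter) and leaves compound 3 the weakest of the three. The earlier swap of bromo for dimethylamino on the phenyl ring showed no such shift, so a change to the ring itself matters more here than that swap did. No available evidence explains this loss. Still open, from the compounds shown here alone, is whether an unsubstituted phenyl, naphthalen-1-yl or a pyridine ring would match compound 1 or compound 3.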